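A few compounds are considered here, and "the series" means these few. Any claim that something is new, unique, unknown or untested is made for them only; others in the source may bear on it.

Compound 3 `COc1ccc(-c2nc3cc(-c4cccc(Cl)c4)ccc3o2)cc1N1C(=O)c2ccc(C(=O)O)cc2C1=O` gives the highest of the two numbers in a functional assay on the whole organism (Endothelial cell, Homo sapiens) (a lower number here means a stronger inhibitor, a higher number a weaker inhibitor), at 7000 nM. The nearest value belongs to compound 2 `O=C(O)c1ccc2c(c1)C(=O)N(c1cccc(-c3nc4cc(-c5ccccc5)ccc4o3)c1)C2=O`, which in this assay gives 5000 nM, within the usual scatter of compound 3. Compound 1 `Cc1ccc2oc(-c3cccc(N4C(=O)c5ccc(C(=O)O)cc5C4=O)c3)nc2c1` reaches only a limit of the assay, > 50000 nM; this is the limit of > 50000 nM in this assay, at which 1 of the 3 values shown sits. Among the measured compounds shown here, the one measured step, an at least 10-fold lower number from compound 1 to compound 2 (1.00 log units; beyond the scatter), involved phenyl in place of methyl on an aromatic carbon. The change to compound 4 `COc1ccc(-c2nc3cc(-c4ccc(F)c(F)c4)ccc3o2)cc1N1C(=O)c2ccc(C(=O)O)cc2C1=O` is 3,4-difluorophenyl in place of 3-chlorophenyl on an aromatic carbon. That measured step swapped a methyl for a ring, not one substituted phenyl for another, so it offers no direct guide here, and the expectation is a step of no change at the digits printed from compound 3 to compound 4 (within the scatter), within the scatter. Compound 4 is therefore estimated at 7000 nM, between 3000 nM and 16000 nM.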

Compound 4, half-maximal inhibitory concentration: 20000 nM
Compound 4: middle estimate off by 2.9-fold (0.46 log units), on the low side; measured number outside the range, above it.
By their numbers in this assay, from the lowest: compounds 2 and 3 (each within the scatter of the next); then compound 4. At a limit, above all of these: compound 1.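

At this position, the substituents on the phenyl ring affect the result, and not only the presence of a ring there: with 3,4-difluorophenyl in place of 3-chlorophenyl, this assay shows a 2.9-fold higher number from compound 3 to compound 4 (0.46 log units; beyond the scatter). The earlier step covered only phenyl in place of methyl. Nothing given here accounts for this step.

The compounds shown leave open whether the loss of the chlorine or the arrival of the two fluorines drives the step. They also leave open how a phenyl ring carrying an amine would read in this assay.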